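The source may report more compounds than this note shows. Statements on the series, on what has been measured and on what is new or still open speak of the compounds shown alone.

Measured in an ADME assay on J774 cells (Mus musculus) for cytotoxicity; a lower number here means that less compound is needed, a higher number that more compound is needed for the effect:
- compound 1 `CCCCc1cc2c(=O)c(CC)c[nH]c2cc1OCCOc1ccccc1`: 360 nM
- compound 2 `CCCCc1cc2c(=O)c(C(=O)OCC)c[nH]c2cc1OCCOc1ccccc1`: > 20000 nM
- compound 3 `CCCc1cc2c(=O)c(C(=O)OC)c[nH]c2cc1OCCOc1ccccc1`: > 20000 nM

Compound 2 has no exact number in this assay, since its > 20000 nM is a limit. Compound 3 also gives only a limit, > 20000 nM. The upper end of the series is therefore set by the limit of > 20000 nM in this assay, at which 2 of the 3 values shown sit.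

Compound 4 `CCCCc1cc2c(=O)c(C(=O)O)c[nH]c2cc1OCCOc1ccccc1` differs from compound 2 by hydrogen in place of ethyl on an oxygen next to a carbonyl group. In words, this is hydrogen in place of ethyl on an oxygen next to a carbonyl group, which turns ethoxycarbonyl into carboxy.

Within the data shown here, only one measured step bears on this change, and only indirectly: an at least 55-fold higher number from compound 1 to compound 2 (1.74 log units; beyond the scatter), a large step with ethoxycarbonyl in place of ethyl on an aromatic carbon. Among the measured compounds shown here, no measured pair covers ethoxycarbonyl to carboxy itself. Compound 4 keeps a carbonyl-bearing group at the place where that large step arose, so it is expected to stay with compound 2 rather than move towards compound 1, and no step beyond the scatter is expected in this assay. The estimated step is a number no higher from compound 2 to compound 4 (the limit leaves the size open). A report of only a limit is the most likely outcome.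

For compound 4 the expected value is 20000 nM, with an estimated range of 7000 nM to 40000 nM.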

Compound 4, half-maximal effective concentration: > 20000 nM
Compound 4 gave a limit, no number (the forecaster's own chance of this, stated with the estimate: 85%); the middle value lies on the limit itself.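

In this assay compound 4 gives > 20000 nM, which is a limit of the assay and not a number. On the aromatic carbon that carries ethyl in compound 1, carboxy now matches what ethoxycarbonyl showed, with an at least 55-fold higher number from compound 1 to compound 4 (1.74 log units; beyond the scatter), so the large step does not depend on the ethyl on the oxygen next to a carbonyl group. The step between the ester and the carboxy compound cannot be read, so hydrogen in place of ethyl at that oxygen has no measurable size here, and the upper end of the series remains fixed: the limit of > 20000 nM in this assay, at which 3 of the 4 values shown sit.

As far as these compounds go, how far compound 2 and compound 4 lie beyond the limit, and whether they differ from each other at all, remains open. Also open, from the compounds shown here alone, is whether a primary amide, a hydroxymethyl group or a nitrile on the same aromatic carbon would stay at the limit or come back towards compound 1, which would show how much of the step follows from the carbonyl itself.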